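The source may hold more compounds than are shown below. What is called first, only, known or untested is meant among the compounds shown, and "the series" means these compounds.

Of the compounds shown here, three built on one shared core have been tested in a functional assay on A549 cells (Homo sapiens) for cytotoxicity, read by MTT assay, with a stated time of 48 h; on this read-out lower numbers stand for stronger inhibition and higher numbers for weaker inhibition. Compound 1 `Cc1cccc(Cn2cc(COc3ccc4c(=O)ccoc4c3)nn2)c1` gives 20300 nM. Compound 2 `Cc1ccccc1Cn1cc(COc2ccc3c(=O)ccoc3c2)nn1` reaches only a limit of the assay, > 100000 nM (the limit of > 100000 nM in this assay, at which 1 of the 3 values shown sits). Compound 3 `O=c1ccoc2cc(OCc3cn(Cc4ccc(Cl)cc4Cl)nn3)ccc12` gives 5260 nM, the lowest of the two actual numbers, with compound 1 the nearest. Compound 4 `O=c1ccoc2cc(OCc3cn(Cc4cccc(F)c4)nn3)ccc12` differs from compound 3 in one place: 3-fluorophenyl in place of 2,4-dichlorophenyl on a saturated chain carbon bound to an aromatic nitrogen. The measured steps that bear on this change run the other way, toward the 2,4-dichlorophenyl group: a 3.9-fold lower number from compound 1 to compound 3 (0.59 log units; beyond the scatter) and an at least 19-fold lower number from compound 2 to compound 3 (1.27 log units; beyond the scatter). Swapping the two chlorines for a single fluorine should undo part of that gain, so a modest rise in the number is expected for compound 4, a 2.9-fold higher number from compound 3 to compound 4 (0.46 log units; beyond the scatter). The estimate for compound 4 is 15000 nM, within 5000 nM to 50000 nM.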

Compound 4, half-maximal inhibitory concentration: > 100000 nM
Compound 4 was reported as a limit; the forecaster's own chance of this, stated with the estimate: 10%; middle value at least 6.6-fold (0.82 log units) away from the limit.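

The 3-fluorophenyl group proves a far poorer fit at this position than the 2,4-dichlorophenyl group, giving an at least 19-fold higher number from compound 3 to compound 4 (1.27 log units; beyond the scatter). Fluoro in place of methyl on an aromatic carbon also matters, giving an at least 4.9-fold higher number from compound 1 to compound 4 (0.69 log units; beyond the scatter). Compound 4 reaches a limit rather than a number, as compound 2 does, so the step between them cannot be read: the limit of > 100000 nM in this assay, at which 2 of the 4 values shown sit.

The compounds shown leave open whether a phenyl ring carrying only one chlorine would keep the lower number seen with two. On these data alone, the effect of a methoxy group or an amine on that ring is also open.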